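The compounds below may be only part of what the source reports. "The series", "measured", "known", "first", "only" and "open" are said of these compounds alone.

Compound 2 `COc1cc(-c2nnc(-c3c[nH]c4ccccc34)o2)ccc1OCc1ccccc1` stands at the limit in a functional assay on DU-145 cells (Homo sapiens) for cytotoxicity, read by MTT assay; on this read-out lower numbers stand for stronger inhibition and higher numbers for weaker inhibition. In this assay compound 2 gives > 1000000 nM, which is a limit of the assay and not a number. The same holds for compound 1 `COc1ccc(-c2nnc(-c3c[nH]c4ccccc34)o2)cc1OC`, which gives > 1000000 nM in this assay, again a limit rather than a number. Going by the values given here, the one step among the measured compounds, a step that the two limits leave unreadable from compound 1 to compound 2, is therefore not readable in size or direction, since both ends rest on the same limit (the limit of > 1000000 nM in this assay, at which 2 of the 2 values shown sit).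

Compound 3 `COc1cc(-c2nnc(-c3c[nH]c4ccccc34)o2)ccc1O` differs from compound 2 by a single change, (hydrogen in place of benzyl on an oxygen on an aromatic ring). Among the compounds with values here, no measured step speaks to this change: the only step available is the unreadable one between compound 1 and compound 2, so there is nothing on which to build an expectation of a shift in either direction, and nothing to suggest that compound 3 leaves the limit where compound 2 sits. The step from compound 2 to compound 3 is accordingly expected to be a number no higher from compound 2 to compound 3 (the limit leaves the size open), that is, none beyond the scatter. Compound 3 is estimated to give 1000000 nM in this assay, within a range of 300000 nM to 3000000 nM.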

Compound 3, half-maximal inhibitory concentration: > 1000000 nM
Compound 3 was reported as a limit; the forecaster's own chance of this, stated with the estimate: 85%; the middle value lies on the limit itself.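

In this assay, going by these compounds alone, compound 3 also stands at a limit and not at a number, so no step among compound 1, compound 2 and compound 3 can be read in size or direction: the limit of > 1000000 nM in this assay, at which 3 of the 3 values shown sit. In this assay the compounds shown leave open how methyl, benzyl and hydrogen on that oxygen compare, and at what concentration any of the three would reach half-maximal inhibition.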